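The compounds below may be only part of what the source reports. "The series", "measured", "known", "first", "only" and "open" are said of these compounds alone.

Measured in a functional assay on B16-F10 cells (Mus musculus) for antiproliferative activity, read by CCK-8 assay, with a stated time of 48 h; a higher number here means a weaker inhibitor, a lower number a stronger inhibitor:
- compound 1 `COc1ccc(/C=C\c2cc(OC)c(OC)c(OC)c2)cc1OCc1ccc(CNC(C)(C)C(=O)O)cc1`: > 10000 nM (a limit of the assay, not a number)
- compound 2 `COc1ccc(/C=C\c2cc(OC)c(OC)c(OC)c2)cc1OCc1ccc(C=O)cc1`: 4200 nM

For the measured compounds named here, compound 2, at 4200 nM, holds the only actual number so far. The other result is a limit.

Next in line is compound 3 `COc1ccc(/C=C\c2cc(OC)c(OC)c(OC)c2)cc1OCc1ccc(CN2C[C@H](O)C[C@@H]2C(=O)O)cc1`, not yet measured. The change is (2-carboxy-4-hydroxypyrrolidin-1-yl)methyl in place of formyl on an aromatic carbon, para to a large group.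

Going by the values given here, one measured step bears on this: an at least 2.3-fold lower number from compound 1 to compound 2 (0.37 log units; beyond the scatter). That step put formyl in place of ((1-carboxy-1-methylethyl)amino)methyl, another carboxy-bearing group. The change to compound 3 runs the opposite way, so a higher number in this assay is expected, of about the size of that step or more. A single step is thin ground, and the range is kept wide for that reason.

The expected step is a 3.6-fold higher number from compound 2 to compound 3 (0.55 log units; beyond the scatter). For compound 3 the estimated value is 15000 nM, with an expected range of 5000 nM to 50000 nM.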

Compound 3, half-maximal inhibitory concentration: > 10000 nM
Compound 3: no number, only a limit (the forecaster's own chance of this, stated with the estimate: 70%); the middle value is on the limit's open side.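

In this assay compound 3 gives > 10000 nM, a limit of the assay and not a number. The new result is an at least 2.3-fold higher number from compound 2 to compound 3 (0.37 log units; beyond the scatter), so on this aromatic carbon, para to a large group, the (2-carboxy-4-hydroxypyrrolidin-1-yl)methyl group with its five-membered ring, like the open-chain ((1-carboxy-1-methylethyl)amino)methyl group of compound 1, gives no measurable number, and neither compound goes against this among the three shown. The step between the two carboxy-bearing compounds cannot be read, and the cyclic and open-chain groups cannot be ranked against each other: the limit of > 10000 nM in this assay, at which 2 of the 3 values shown sit.

The compounds shown do not separate the carboxylic acid from the amine nitrogen that accompanies it in both groups, so a plain aminomethyl group or a methyl ester of the carboxylic acid at this place would be needed to tell the two apart. Also open, going by these compounds, is whether any group here can give a lower number than formyl in compound 2, which reads 4200 nM, for instance a hydroxymethyl group or a simple amide.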